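Swapping the Amide for a Methylimidazole on the Shared Core

The source may hold more compounds than are shown below. What is called first, only, known or untested is meant among the compounds shown, and "the series" means these compounds.

Compound 1 `CCCCN(c1nc2c(NS(C)(=O)=O)cccc2o1)[C@H](C)c1ccc(-c2ccccc2-c2nnn[nH]2)cc1`: 14 nM
Compound 2 `CCCCN(c1nc2c(C(=O)NC)cccc2o1)[C@H](C)c1ccc(-c2ccccc2-c2nnn[nH]2)cc1`: 110 nM

In a functional assay on CAL1 cells for inhibition of chemerin-like receptor 1 (Homo sapiens), with a stated time of 45 min (a lower number here means a stronger inhibitor, a higher number a weaker inhibitor), compound 2 gives 110 nM, the higher of the two numbers, reached through a 7.9-fold higher number from compound 1 to compound 2 (0.90 log units; beyond the scatter). Compound 3 `CCCCN(c1nc2c(-c3nccn3C)cccc2o1)[C@H](C)c1ccc(-c2ccccc2-c2nnn[nH]2)cc1` arises from compound 2 by 1-methyl-1H-imidazol-2-yl in place of methylcarbamoyl on an aromatic carbon. Among the compounds with values here, only that single step at this position bears on the change, and it was modest, so a shift of similar size is plausible in either direction. Compound 3 is therefore expected to stay close to compound 2, with the step of a 1.1-fold lower number from compound 2 to compound 3 (0.04 log units; within the scatter). The estimate for compound 3 is 100 nM, within a range from 25 nM to 400 nM.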

Compound 3, half-maximal inhibitory concentration: 10 nM
The estimate for compound 3 lay 10-fold (1.00 log units) above the measured number, outside the stated range (below it).
By their numbers in this assay, from the lowest: compounds 3 and 1 (each within the scatter of the next); then compound 2.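

In this assay, this position is clearly sensitive to what it carries: 1-methyl-1H-imidazol-2-yl in place of methylcarbamoyl gives an 11-fold lower number from compound 2 to compound 3 (1.04 log units; beyond the scatter), a far larger change than one step had suggested. Set against methanesulfonamido, the same ring gives a 1.4-fold lower number from compound 1 to compound 3 (0.15 log units; within the scatter), so two very different groups, one of them with 0 hydrogen-bond donors, perform alike here. No measurement on hand explains this gain. Still open, on these data alone, is whether the methyl on the ring matters. An unsubstituted imidazole or a plain phenyl ring at this carbon would begin to show that.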